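Compound 3: 3,4-dichlorophenyl to 4-chlorophenyl

This account rests on a few compounds, and the source may have more. Where it says the series, first, only, none or still open, it means among the compounds named here.

In a physicochemical assay for solubility, read by HPLC, measured as kinetic solubility, with a stated time of 2 h, at pH 2 (on this read-out higher numbers stand for higher solubility and lower numbers for lower solubility), compound 1 `CC(C)(C)n1nnnc1C(NCCNc1ccnc2cc(Cl)ccc12)c1ccc(Cl)c(Cl)c1` gives 194000 nM and compound 2 `Clc1ccc2c(NCCNC(c3ccc(Cl)c(Cl)c3)c3nnn[nH]3)ccnc2c1` gives 191000 nM so the two stand within the scatter of each other. Going by the values given here, the one measured step of a 1.0-fold lower number from compound 1 to compound 2 (0.01 log units; within the scatter) is hydrogen in place of tert-butyl on an aromatic nitrogen and lies within the scatter. That step sits at a different place from the next change, so it bears only indirectly. Compound 3 `Clc1ccc(C(NCCNc2ccnc3cc(Cl)ccc23)c2nnn[nH]2)cc1` is not yet measured and differs from compound 2 by hydrogen in place of chloro on an aromatic carbon in a change from 3,4-dichlorophenyl to 4-chlorophenyl. Among the compounds with values here, no measured step covers this change. Starting from compound 2 at 191000 nM as its value, no step beyond the scatter is expected in this assay and no direction can be argued. The expected step is a 1.0-fold lower number from compound 2 to compound 3 (0.00 log units; within the scatter) on this estimate. Compound 3 is estimated at 190000 nM with 120000 nM to 270000 nM as the expected range.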

Compound 3, solubility: > 200000 nM
Compound 3: only a limit was reported (the forecaster's own chance of this, stated with the estimate: 15%); middle value at least 1.0-fold (0.02 log units) away from the limit.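

In this assay compound 3 gives > 200000 nM, which is a limit of the assay and not a number: the limit of > 200000 nM in this assay, at which 1 of the 3 values shown sits.

Hydrogen in place of chloro on an aromatic carbon, the change from 3,4-dichlorophenyl to 4-chlorophenyl, gives an at least 1.0-fold higher number from compound 2 to compound 3 (0.01 log units; that floor lies within the scatter), so only a floor is known for this step and it does not separate the two compounds. Going by these compounds, the earlier step concerned the aromatic nitrogen, so this chloro position now has its first measured step, although its true size stays unknown.

Still open, on these data alone, is how a group other than chloro or hydrogen at this position, such as an amine or a carboxylic acid, would read in this assay. Also open, as far as these compounds go, is how a phenyl ring without the remaining chloro would read.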